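Swapping the triazole for hydroxypiperidine on the chain

A few compounds are considered here, and "the series" means these few. Any claim that something is new, unique, unknown or untested is made for them only; others in the source may bear on it.

Measured compounds:
compound 1, `Cn1ncc(Cl)c1-c1cc(C(=O)N[C@@H]2CN[C@H](CCn3cncn3)C[C@H]2c2ccc(Cl)c(Cl)c2)oc1Cl`, 4.47 nM;
compound 2, `Cn1ncc(Cl)c1-c1cc(C(=O)NC2CNCCC2c2ccc(C(F)(F)F)cc2)oc1Cl`, 7.2 nM;
compound 3, `CC(=O)NCC[C@@H]1C[C@@H](c2ccc(F)c(F)c2)[C@H](NC(=O)c2cc(-c3c(Cl)cnn3C)c(Cl)o2)CN1`, 2.49 nM.

All three were measured in an assay for inhibition of RAC-alpha serine/threonine-protein kinase (Homo sapiens), read by HTRF, with a stated time of 1 h; on this read-out lower numbers stand for stronger inhibition and higher numbers for weaker inhibition. Compound 1 stands second highest of the three numbers; its nearest neighbour is compound 2 and its furthest is compound 3, and both gaps lie within the scatter. Compound 4, `Cn1ncc(Cl)c1-c1cc(C(=O)N[C@@H]2CN[C@H](CCN3CCC(O)CC3)C[C@H]2c2ccc(Cl)c(Cl)c2)oc1Cl`, carries the change (4-hydroxypiperidin-1-yl in place of 1H-1,2,4-triazol-1-yl on a saturated chain carbon, two bonds along the chain from a saturated ring carbon). Going by the values given here, no step between measured compounds tells how this place responds, though compound 2 and compound 3 show that the chain can be absent or altered without leaving the scatter. The step from compound 1 to compound 4 is therefore expected to be small, a 1.1-fold lower number from compound 1 to compound 4 (0.05 log units; within the scatter), in no firm direction. Compound 4 is estimated at 4 nM, ranging from 1.5 nM to 12 nM.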

Compound 4, half-maximal inhibitory concentration: 5.99 nM
The estimate for compound 4 lay 1.5-fold (0.18 log units) below the measured number, within the range that was stated.
By their numbers in this assay, from the lowest: compounds 3, 1, 4 and 2 (each within the scatter of the next, the first and the last beyond it).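

In this assay, going by these compounds alone, the only step read at this place, on a saturated chain carbon, two bonds along the chain from a saturated ring carbon, is a 1.3-fold higher number from compound 1 to compound 4 (0.13 log units; within the scatter). This shows that a six-membered non-aromatic ring, 4-hydroxypiperidin-1-yl, can stand in place of the five-membered aromatic 1H-1,2,4-triazol-1-yl without a step beyond the scatter. Nothing available offers an explanation for this result. Going by these compounds, whether an open-chain dimethylamino group, a carboxylic acid or a longer chain at this place would leave the number within the scatter remains open.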